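Swapping a dimethoxyphenyl for a cyanophenyl on compound 2

This account rests on a few compounds, and the source may have more. Where it says the series, first, only, none or still open, it means among the compounds named here.

compound 1 `COc1ccc(OC)c(/C=C/C(=O)Nc2cc3c(Nc4ccc(F)c(Cl)c4)ncnc3cc2OC)c1` gives 34300 nM
compound 2 `COc1ccc(/C=C/C(=O)Nc2cc3c(Nc4ccc(F)c(Cl)c4)ncnc3cc2O[C@H]2CCOC2)c(OC)c1` gives 28600 nM
compound 3 `COc1cc2ncnc(Nc3ccc(F)c(Cl)c3)c2cc1NC(=O)/C=C/c1ccccc1[N+](=O)[O-]` gives 36500 nM

These three values come from a functional assay on MCF7 cells (Homo sapiens) for cytotoxicity, read by MTT assay, with a stated time of 72 h (a higher number here means a weaker inhibitor, a lower number a stronger inhibitor), and all lie within the usual scatter of one another. Compound 2 at 28600 nM therefore stands level with the other two and cannot be ranked against them.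

Compound 4 `N#Cc1ccc(/C=C/C(=O)Nc2cc3c(Nc4ccc(F)c(Cl)c4)ncnc3cc2O[C@H]2CCOC2)cc1` differs from compound 2 by a single swap of 4-cyanophenyl in place of 2,4-dimethoxyphenyl on a double-bonded chain carbon bound to a double-bonded chain carbon, counted as 4-cyanophenyl in place of 2,4-dimethoxyphenyl on a double-bonded chain carbon bound to a double-bonded chain carbon with the rest of the molecule unchanged.

Among the measured compounds shown here, only one measured step bears on this swap. That step is a 1.1-fold higher number from compound 1 to compound 3 (0.03 log units; within the scatter) and it puts 2-nitrophenyl in place of 2,5-dimethoxyphenyl at the same kind of chain carbon. For the measured compounds named here, it is a limited guide: no compound carrying 4-cyanophenyl has been measured, and compound 1 and compound 3 differ from compound 2 elsewhere in their structures.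

In this assay the expected change is a 1.0-fold higher number from compound 2 to compound 4 (0.02 log units; within the scatter) and so no step beyond the scatter is expected. For compound 4 the estimated value is 30000 nM with 14000 nM to 62000 nM as the expected range.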

Compound 4, half-maximal inhibitory concentration: 9830 nM
Compound 4: the middle estimate sits 3.1-fold (0.48 log units) above what was measured, and the stated range ends above it.
By their numbers in this assay, from the lowest: compound 4; then compounds 2, 1 and 3 (each within the scatter of the next).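

In this assay, among the compounds shown here, the group on the double-bonded chain carbon turns out to matter: the step of a 2.9-fold lower number from compound 2 to compound 4 (0.46 log units; beyond the scatter) goes beyond the scatter, while the only earlier swap at this kind of carbon, a step of a 1.1-fold higher number from compound 1 to compound 3 (0.03 log units; within the scatter) stayed within it, so that swap gave no sign that this place could move the number at all. The ring itself stays the same kind, one six-membered aromatic ring of carbon only, so the change lies in what that ring carries, with two methoxy groups leaving and one nitrile entering in a single swap. Nothing measured here explains why the number falls with this swap.

The compounds shown cannot separate losing the methoxy groups from gaining the nitrile, since both happen together between the two compounds. A plain phenyl on this chain carbon would help to pull the two apart, and a 4-aminophenyl or a 4-carboxyphenyl would show whether other groups in the place of the nitrile give a similar number.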